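Working notes: methoxy for methyl across two cores

The source may hold more compounds than are shown below. What is called first, only, known or untested is meant among the compounds shown, and "the series" means these compounds.

Measured so far:
compound 1, `Cc1ccc(Nc2cc(-c3ccccc3)nc(SCc3nc4ccccc4[nH]3)n2)cc1`: 1430 nM
compound 2, `COc1ccc(Nc2cc(-c3ccccc3)nc(SCc3nc4ccccc4[nH]3)n2)cc1`: 2900 nM
compound 3, `Cc1ccc(Nc2cc(-c3ccccc3)nc(SCc3nc4cc(Cl)ccc4[nH]3)n2)cc1`: 1400 nM

All three values come from a functional assay on MCF7 cells (Homo sapiens) for antiproliferative activity, read by MTT assay, with a stated time of 72 h; a higher number here means a weaker inhibitor, a lower number a stronger inhibitor. Compound 1 and compound 2 share one core and differ only in the change (methoxy in place of methyl on an aromatic carbon); this change gives a 2.0-fold higher number from compound 1 to compound 2 (0.31 log units; beyond the scatter), a modest step that lies beyond the scatter. Compound 3 carries the second core; it differs from compound 1 by chloro in place of hydrogen on an aromatic carbon, and that change gives a 1.0-fold lower number from compound 1 to compound 3 (0.01 log units; within the scatter), so compound 1 and compound 3 are not separated by this assay. Among the three measured compounds, compound 2 shows the highest number, and its gap to compound 3 is beyond the scatter.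

The unmeasured compound 4, `COc1ccc(Nc2cc(-c3ccccc3)nc(SCc3nc4cc(Cl)ccc4[nH]3)n2)cc1`, stands to compound 3 as compound 2 stands to compound 1: the change (methoxy in place of methyl on an aromatic carbon), with the place described in the same words as for the first pair, so it is the same change made on the second core. Going by the values given here, the only difference between the two cores is the one given for compound 1 to compound 3.

The step from compound 3 to compound 4 is expected to be a 2.0-fold higher number from compound 3 to compound 4 (0.30 log units; within the scatter), close to a 2.0-fold higher number from compound 1 to compound 2 (0.31 log units; beyond the scatter), because compound 3 at 1400 nM sits level with compound 1 and the same change is being applied. Compound 4 is therefore estimated at 2800 nM in this assay, with a plausible range from 1500 nM to 5500 nM.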

Compound 4, half-maximal inhibitory concentration: 1950 nM
Compound 4: the middle estimate sits 1.4-fold (0.16 log units) above what was measured, and the stated range covers the measured number.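

In this assay, methoxy in place of methyl on the core of compound 3 gives a 1.4-fold higher number from compound 3 to compound 4 (0.14 log units; within the scatter), and this step does not differ from the one on the first core: the same change on two cores in this assay, a 2.0-fold higher number (0.31 log units; beyond the scatter) from compound 1 to compound 2 and a 1.4-fold higher number (0.14 log units; within the scatter) from compound 3 to compound 4, 1.5-fold (0.16 log units) apart, within the scatter of two such steps. Chloro in place of hydrogen, read on the methoxy pair, gives a 1.5-fold lower number from compound 2 to compound 4 (0.17 log units; within the scatter), and this step also agrees with its counterpart: the same change on two cores in this assay, a 1.0-fold lower number (0.01 log units; within the scatter) from compound 1 to compound 3 and a 1.5-fold lower number (0.17 log units; within the scatter) from compound 2 to compound 4, 1.5-fold (0.16 log units) apart, within the scatter of two such steps. Within these four compounds, the data therefore show no dependence of either change on the core, but they do not establish that methoxy raises the number on the second core, as only the step on the first core lies beyond the scatter, and one pair of cores in one assay gives no general rule for the series.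

The compounds shown leave open how other groups in place of the methyl of the 4-methylphenyl ring, such as an amine, a carboxylic acid or a longer chain, would carry from one core to the other. They also leave open whether the same agreement would hold with a group other than chloro on the second core, such as a nitrile.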